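This account rests on a few compounds, and the source may have more. Where it says the series, first, only, none or still open, it means among the compounds named here.

Working notes on the series. For the measured compounds named here, in an assay for inhibition of Nicotinamide phosphoribosyltransferase (Homo sapiens), read by mass spectrometry, with stated times of 15 min and 30 min (on this read-out lower numbers stand for stronger inhibition and higher numbers for weaker inhibition), compound 1 `O=C(NCc1ccc(S(=O)(=O)c2ccccc2)cc1)c1nc2cnccc2[nH]1` gives 7100 nM and compound 2 `O=C(NCc1ccc(S(=O)(=O)c2ccccc2)cc1)c1nc2ccncc2s1` gives 210 nM; the step of a 34-fold lower number from compound 1 to compound 2 (1.53 log units; beyond the scatter) is the only exchange at the carbonyl carbon measured so far. Compound 3 `O=C(NCc1ccc(S(=O)(=O)N2CCCCC2)cc1)c1cc2cnccc2o1` gives 140 nM, the lowest number of the three, though its gap to compound 2 lies within the scatter. Compound 4 `O=C(NCc1ccc(S(=O)(=O)N2CCCCC2)cc1)c1ccn2cncc2c1` differs from compound 3 by a group of 9 heavy atoms (7 carbon, 2 nitrogen; one five-membered aromatic ring with 2 hetero atoms, one six-membered aromatic ring with 1 hetero atom) in place of a group of 9 heavy atoms (7 carbon, 1 nitrogen, 1 oxygen; one five-membered aromatic ring with 1 hetero atom, one six-membered aromatic ring with 1 hetero atom), on a carbonyl carbon. Going by the values given here, the one measured step at that place, from compound 1 to compound 2, was large, so a change beyond the scatter is possible in either direction; with no measured pairing of these two groups, the expected step of a 1.8-fold higher number from compound 3 to compound 4 (0.25 log units; within the scatter) is set near no change but with wide bounds. Compound 4 is estimated at 250 nM, with a range from 40 nM to 2500 nM.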

Compound 4, half-maximal inhibitory concentration: 1700 nM
Beside the measured number, compound 4's estimate is 6.8-fold (0.83 log units) below it; measured number inside the range.
By their numbers in this assay, from the lowest: compounds 3 and 2 (each within the scatter of the next); then compound 4; then compound 1.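

For the compounds shown here, the step of a 12-fold higher number from compound 3 to compound 4 (1.08 log units; beyond the scatter) is the first upward move measured at the carbonyl carbon, so this position can also lose ground, and in a pair whose remainder differs from that of compound 1 and compound 2. The exchange keeps the heavy-atom count and the hydrogen-bond donor and acceptor counts unchanged, so those counts alone do not settle the number at this place. Nothing available accounts for the size of this step.

Open, as far as these compounds go, is whether a single pyridine ring on the carbonyl carbon would hold the number of compound 3. Also open, from the compounds shown here alone, is whether the same exchange would move the number as far with the phenyl sulfonyl of compound 2.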